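This account rests on a few compounds, and the source may have more. Where it says the series, first, only, none or still open, it means among the compounds named here.

Compound 1 `C[C@]1(CO)OC[C@@H](n2ccc(N)nc2=O)O1` is the starting point. In a functional assay on P388 cells (Mus musculus) for inhibition (a lower number here means a stronger inhibitor, a higher number a weaker inhibitor), compound 1 gives 5000 nM, which is the lowest of the two numbers shown here. Its nearest neighbour is compound 2 `C[C@]1(CO)OC[C@@H](n2cc(F)c(N)nc2=O)O1`, which in this assay gives 50000 nM; the step of a 10-fold higher number from compound 1 to compound 2 (1.00 log units; beyond the scatter) comes from a fluoro in place of hydrogen on an aromatic carbon. Compound 3 `C[C@]1(CO)OCC(n2cc(F)c(N)nc2=O)O1` gives only a limit in this assay, namely > 100000 nM. The step of an at least 2.0-fold higher number from compound 2 to compound 3 (0.30 log units; that floor lies within the scatter) is therefore open at its upper end because of the limit of > 100000 nM in this assay, at which 1 of the 3 values shown sits, and the two compounds differ only in that one of them is drawn with a defined configuration and the other without, as noted in the fact that one of compounds 2 and 3 is drawn with a defined configuration and the other without, at the place where they differ.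

The compound not yet measured is compound 4 `CC1(CO)OC[C@@H](n2ccc(N)nc2=O)O1`. Compared with compound 1, the change is the two compounds have the same atoms and bonds; at least one stereo element is drawn with a configuration in one of them and without one in the other: 1 of 2 stereo elements differ; a stereocentre at a saturated ring carbon is drawn S in compound 1 and without a configuration in compound 4: the same atoms and bonds, with one stereocentre at a saturated ring carbon drawn without a configuration. Among the measured compounds shown here, this is the same kind of change as the one from compound 2 to compound 3, whose size is only known as a floor that lies within the scatter. A modest rise in number is therefore expected, so that compound 4 is estimated at 10000 nM in this assay, within 4000 nM to 30000 nM. That estimate corresponds to the step of a 2.0-fold higher number from compound 1 to compound 4 (0.30 log units; within the scatter).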

Compound 4, half-maximal inhibitory concentration: > 100000 nM
Compound 4 was reported as a limit; the forecaster's own chance of this, stated with the estimate: 5%; middle value at least 10-fold (1.00 log units) away from the limit.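

In this assay, compound 1 and compound 4 differ in one place only, a stereocentre at a saturated ring carbon that is drawn with a configuration in one and without one in the other, and this single difference now goes with a large change: the fact that one of compounds 1 and 4 is drawn with a defined configuration and the other without, at the place where they differ. Among the compounds shown here, the step is an at least 20-fold higher number from compound 1 to compound 4 (1.30 log units; beyond the scatter), whereas the same kind of change in the fluoro pair gave only an at least 2.0-fold higher number from compound 2 to compound 3 (0.30 log units; that floor lies within the scatter), so only the pair without fluoro shows that this stereocentre can matter beyond the scatter. Compound 4 is reported only as a limit, > 100000 nM, so the step has a floor but no known upper end.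

The compounds shown do not include one drawn with the opposite configuration at this ring carbon, so how that form alone would read remains unknown. On these data alone, it is also open whether the drawn configuration matters as much when a chloro or methyl group takes the place of the fluoro on the aromatic carbon, or when an aminomethyl group replaces the hydroxymethyl group.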